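From compound 1 to compound 4: a ring change

This account rests on a few compounds, and the source may have more. Where it says the series, first, only, none or still open, it means among the compounds named here.

Compound 1 `Cc1c(C)c2c(c(C)c1OC(=O)CCC(=O)O)CCC(C)(C(=O)NC1CC(C)(C)N([O])C(C)(C)C1)O2` gives > 300000 nM in a functional assay on MCF7 cells (Homo sapiens) for cytotoxicity, read by MTT assay, with a stated time of 72 h (a higher number here means a weaker inhibitor, a lower number a stronger inhibitor), as a limit and not a number. Compound 3 `CC1(C)CC(CNC(=O)CCC(=O)O)C(C)(C)N1[O]` gives > 300000 nM in this assay as a limit too. Compound 1 thus stands at the limit of > 300000 nM in this assay, at which 2 of the 3 values shown sit, and has no number of its own. Compound 2 `Cc1c(C)c2c(c(C)c1O)CCC(C)(C(=O)NC1CC(C)(C)N([O])C(C)(C)C1)O2` gives 58000 nM in this assay as a true number. Within the data shown here, the only measured step is an at least 5.1-fold lower number from compound 1 to compound 2 (0.71 log units; beyond the scatter) and it comes with hydrogen in place of (2-carboxyethyl)carbonyl on an oxygen on an aromatic ring.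

Compound 4 `Cc1c(C)c2c(c(C)c1OC(=O)CCC(=O)O)CCC(C)(C(=O)NCC1CC(C)(C)N([O])C1(C)C)O2` keeps that (2-carboxyethyl)carbonyl and changes on an amide-type nitrogen instead. The change is a group of 11 heavy atoms (9 carbon, 1 nitrogen, 1 oxygen; one five-membered non-aromatic ring with 1 hetero atom) in place of a group of 11 heavy atoms (9 carbon, 1 nitrogen, 1 oxygen; one six-membered non-aromatic ring with 1 hetero atom), on an amide-type nitrogen and the two compounds have the same atoms, joined differently. Among the measured compounds shown here, no measured step covers this change. Compound 4 retains the group that compound 1 carries at > 300000 nM so no step beyond the scatter is expected in this assay and another limit is likely. The expected step is a step that the limit leaves unreadable from compound 1 to compound 4 on that reading. Estimated for compound 4 is 400000 nM with 150000 nM to 1000000 nM as its expected range.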

Compound 4, half-maximal inhibitory concentration: > 300000 nM
Compound 4: only a limit was reported (the forecaster's own chance of this, stated with the estimate: 85%); the middle value lies beyond the limit too.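

In this assay compound 4 gives > 300000 nM, a limit and not a number. Compound 1 also stands at a limit, so no step between compound 1 and compound 4 can be read: the limit of > 300000 nM in this assay, at which 3 of the 4 values shown sit.

The compounds shown leave open whether the five-membered ring in place of the six-membered ring on the amide-type nitrogen alters the read-out at all.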